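The source may report more compounds than this note shows. Statements on the series, on what has been measured and on what is new or still open speak of the compounds shown alone.

Measured so far:
compound 1 `COc1cccc(NC2=CC(=O)c3c(nc4n3[C@H]3OC[C@@H](O)[C@H]3OC4)C2=O)c1` — 3340 nM
compound 3 `CCOc1ccccc1NC1=CC(=O)c2nc3n(c2C1=O)[C@H]1OC[C@@H](O)[C@H]1OC3` — 4630 nM
compound 2 `O=C1C=C(NC2CCCC2)C(=O)c2c1nc1n2[C@H]2OC[C@@H](O)[C@H]2OC1` — > 16000 nM, a limit of the assay rather than a number

All three share one core and differ only in the group on the double-bonded ring carbon. In a functional assay on ECa-109 cells for inhibition, with ECa-109 cell line (Homo sapiens) as the target, read by sulforhodamine B assay (on this read-out higher numbers stand for weaker inhibition and lower numbers for stronger inhibition), compound 1 and compound 3 give numbers that lie within the scatter of each other. For compound 2 there is only (the limit of > 16000 nM in this assay, at which 1 of the 3 values shown sits).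

For the measured compounds named here, compound 4 `O=C1C(N2CCC2)=CC(=O)c2c1nc1n2[C@H]2OC[C@@H](O)[C@H]2OC1` is not yet measured. azetidin-1-yl in place of (3-methoxyphenyl)amino on a double-bonded ring carbon The one measured step that bears on it is an at least 3.4-fold lower number from compound 2 to compound 3 (0.53 log units; beyond the scatter). Compound 4 moves the other way, from an aromatic amine to a small saturated ring, so a higher number, meaning weaker inhibition, is expected. Compound 4 is estimated at 12000 nM (range 4000 nM to 40000 nM), which is expected to be a 3.6-fold higher number from compound 1 to compound 4 (0.56 log units; beyond the scatter).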

Compound 4, half-maximal inhibitory concentration: > 16000 nM
Compound 4 was reported as a limit; the forecaster's own chance of this, stated with the estimate: 40%; middle value at least 1.3-fold (0.12 log units) from the limit.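

In this assay, azetidin-1-yl gives an at least 4.7-fold higher number from compound 1 to compound 4 (0.68 log units; beyond the scatter), so at this position a small saturated ring on nitrogen does not keep the activity of the (3-methoxyphenyl)amino group. The value of compound 4 is a limit of the assay, not a number. Compound 2 and compound 4, which carry saturated rings, both end at that limit, while the aromatic amines compound 1 and compound 3 give real numbers: the limit of > 16000 nM in this assay, at which 2 of the 4 values shown sit.

Going by these compounds, how weak compound 4 really is stays unknown. Also open, on these data alone, is whether the aromatic ring or the amine hydrogen matters more, which a benzylamino or piperidin-1-yl group could help separate.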